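One stereocentre drawn, from compound 1 to compound 4

The compounds below may be only part of what the source reports. "The series", "measured", "known", "first", "only" and "open" are said of these compounds alone.

Measured in a functional assay on A549 cells (Homo sapiens) for cytotoxicity, read by MTT assay, with a stated time of 72 h; on this read-out higher numbers stand for weaker inhibition and lower numbers for stronger inhibition:
- Compound 1 `CC1(C)OCC(Cn2cc(Cn3c4c(c5ccccc53)C(=O)c3c[n+]([O-])c5ccccc5c3C4=O)nn2)O1`: 80 nM
- Compound 2 `CN1CCN(CCCCn2c3c(c4ccccc42)C(=O)c2c[n+]([O-])c4ccccc4c2C3=O)CC1`: 90 nM
- Compound 3 `CCCCN1CCN(CCCCn2c3c(c4ccccc42)C(=O)c2c[n+]([O-])c4ccccc4c2C3=O)CC1`: 550 nM

Compound 1 and compound 2 lie within the usual scatter of each other, so neither can be ranked ahead of the other. Going by the values given here, compound 3, at 550 nM, shows a higher number than either of them, so compound 1 stands at the low end of the numbers known so far.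

Compound 4 `CC1(C)OC[C@@H](Cn2cc(Cn3c4c(c5ccccc53)C(=O)c3c[n+]([O-])c5ccccc5c3C4=O)nn2)O1` is the next to be considered, and its relation to compound 1 is simple: the two compounds have the same atoms and bonds; at least one stereo element is drawn with a configuration in one of them and without one in the other: 1 of 1 stereo elements differ; a stereocentre at a saturated ring carbon is drawn without a configuration in compound 1 and R in compound 4. Among the compounds with values here, the only measured step, a 6.1-fold higher number from compound 2 to compound 3 (0.79 log units; beyond the scatter), is propyl in place of hydrogen on a saturated chain carbon bound to an amine nitrogen in a ring. That is a change of atoms, not of configuration, so it gives no real guide here. Within the data shown here, no measured pair shows what a stereo element does in this assay, and the data give no direction for this change.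

The expectation therefore rests on compound 1 at 80 nM, with no shift beyond the scatter. The estimated change is a 1.1-fold lower number from compound 1 to compound 4 (0.03 log units; within the scatter). Compound 4 is expected at 75 nM, within an estimated range of 35 nM to 170 nM.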

Compound 4, half-maximal inhibitory concentration: 4700 nM
Estimate against measurement, compound 4: 63-fold (1.80 log units) below, and the stated range ends below it.
By their numbers in this assay, from the lowest: compounds 1 and 2 (each within the scatter of the next); then compound 3; then compound 4.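

In this assay the result is a 59-fold higher number from compound 1 to compound 4 (1.77 log units; beyond the scatter), a larger step than the change of atoms in a 6.1-fold higher number from compound 2 to compound 3 (0.79 log units; beyond the scatter). It shows that the saturated ring carbon carrying the stereocentre is a place where the drawn configuration alone goes with a large difference in the number, with no atom or bond altered, which compounds 1 to 3 could not show. The only thing separating the two compounds is this: the fact that one of compounds 1 and 4 is drawn with a defined configuration and the other without, at the place where they differ

The drawing of compound 1 does not say which configuration or mixture of configurations it holds, so the compounds shown leave open what a form drawn as S would give and how much of the low number of compound 1 would belong to it. They also leave open whether the R configuration would matter in the same way if a free diol or an amine took the place of the ring that carries this stereocentre.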